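The source may report more compounds than this note shows. Statements on the series, on what has been measured and on what is new or still open speak of the compounds shown alone.

Compound 1 `N=C(N)N/N=C/c1cccc(C(=N)N)c1` carries an unsubstituted guanidine nitrogen; in an assay for inhibition of S-adenosylmethionine decarboxylase proenzyme (Rattus norvegicus) (a lower number here means a stronger inhibitor, a higher number a weaker inhibitor), compound 1 gives 36 nM. Compound 2 `CC/C(=N\N=C(N)N)c1cccc(C(=N)N)c1` gives in this assay 88 nM, and compound 3 `N=C(NO)N/N=C/c1cccc(C(=N)N)c1` gives in this assay 92 nM. Among the three measured numbers compound 3 stands highest, but its distance to compound 2 lies within the scatter, so no order between those two can be read; only the step of a 2.6-fold higher number from compound 1 to compound 3 (0.41 log units; beyond the scatter) is beyond the scatter.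

Compound 4 `N=C(NN)N/N=C/c1cccc(C(=N)N)c1` differs from compound 3 by amino in place of hydroxy on an amine nitrogen. For the measured compounds named here, the one measured step that bears on this position is a 2.6-fold higher number from compound 1 to compound 3 (0.41 log units; beyond the scatter), a modest weakening when hydroxy replaced hydrogen. Going by the values given here, no measured pair compares hydroxy with amino on that nitrogen, and the two groups are alike in what is counted for them. The expected step is therefore a 1.0-fold lower number from compound 3 to compound 4 (0.01 log units; within the scatter), none beyond the scatter. Compound 4 is accordingly expected to give in this assay about 90 nM, within a range from 40 nM to 220 nM.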

Compound 4, half-maximal inhibitory concentration: 210 nM
Compound 4: the middle estimate sits 2.3-fold (0.37 log units) below what was measured, within the range that was stated.
By their numbers in this assay, from the lowest: compound 1; then compounds 2 and 3 (each within the scatter of the next); then compound 4.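

In this assay, hydroxy and amino on an amine nitrogen are not interchangeable: a 2.3-fold higher number from compound 3 to compound 4 (0.36 log units; beyond the scatter) separates two groups that match in everything counted for them, so those counts do not settle what this position accepts. Measured against the unsubstituted nitrogen, amino gives a 5.8-fold higher number from compound 1 to compound 4 (0.77 log units; beyond the scatter) and so goes further than hydroxy did. Among compound 1, compound 3 and compound 4, then, hydrogen gives the lowest number, hydroxy the next and amino the highest, each separated by more than the scatter.

On these data alone, whether a methyl or a methoxy on that nitrogen would fall with hydroxy, with amino or elsewhere remains open, as does whether this order would hold on the core of compound 2. No evidence on hand bears on why the two groups differ here.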